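Swapping the Ring Substituent on the Amine Nitrogen

The source may report more compounds than this note shows. Statements on the series, on what has been measured and on what is new or still open speak of the compounds shown alone.

Compound 1 `C=C1[C@@H](OC(C)=O)C[C@@H]2[C@](C)(CO[Si](C)(C)C(C)(C)C)[C@H](OC(C)=O)CC[C@@]2(C)[C@@H]1C[C@@H](Nc1ccccc1F)C1=CCOC1=O` carries a 2-fluorophenyl group on an amine nitrogen. In a functional assay on A549 cells (Homo sapiens) for cytotoxicity, read by sulforhodamine B assay (a higher number here means a weaker inhibitor, a lower number a stronger inhibitor), compound 1 gives 3190 nM, the lowest of the two plain numbers measured. Compound 2 `C=C1[C@@H](OC(C)=O)C[C@@H]2[C@](C)(COC=O)[C@H](OC(C)=O)CC[C@@]2(C)[C@@H]1C[C@@H](Nc1ccccc1C(=O)O)C1=CCOC1=O` differs from compound 1 at two places, and in this assay compound 2 gives 45900 nM, a gap well beyond the usual scatter. For compound 3 `C=C1[C@@H](OC(C)=O)C[C@@H]2[C@](C)(COC=O)[C@H](OC(C)=O)CC[C@@]2(C)[C@@H]1C[C@@H](Nc1ccc(C(=O)O)cc1)C1=CCOC1=O` this assay reports only a limit, > 50000 nM. Compound 3 thus sits at the limit of > 50000 nM in this assay, at which 1 of the 3 values shown sits. For the measured compounds named here, the single one-place step measured, an at least 1.0-fold higher number from compound 2 to compound 3 (0.03 log units; that floor lies within the scatter), runs into that limit, so its true size is unknown.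

Compound 4 `C=C1[C@@H](OC(C)=O)C[C@@H]2[C@](C)(CO[Si](C)(C)C(C)(C)C)[C@H](OC(C)=O)CC[C@@]2(C)[C@@H]1C[C@@H](Nc1ccc(Br)cc1)C1=CCOC1=O` differs from compound 1 in one place: 4-bromophenyl in place of 2-fluorophenyl on an amine nitrogen. Going by the values given here, no measured step shares this change; the step from compound 2 to compound 3 concerns a different substituent and starts from a much weaker compound, so it offers little guidance. With nothing pointing strongly either way, compound 4 is expected to stay close to compound 1, with a slight lean toward a higher number. Compound 4 is expected to give 4500 nM, with a range from 1500 nM to 15000 nM. The expected step of a 1.4-fold higher number from compound 1 to compound 4 (0.15 log units; within the scatter) is small enough that the scatter could cover it.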

Compound 4, half-maximal inhibitory concentration: 4150 nM
Estimate against measurement, compound 4: 1.1-fold (0.04 log units) above; measured number inside the range.
By their numbers in this assay, from the lowest: compounds 1 and 4 (each within the scatter of the next); then compound 2. At a limit, above all of these: compound 3.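

In this assay the swap of 2-fluorophenyl for 4-bromophenyl on the amine nitrogen gives a 1.3-fold higher number from compound 1 to compound 4 (0.11 log units; within the scatter) and so leaves the number where it was, as far as this kind of measurement can tell. For the compounds shown here, until now only one aryl group with a halogen had been seen at this position, and here a second one, carrying a different halogen at a different place on the ring, cannot be told apart from it on the same core with its silyl ether. Nothing measured explains why the two groups read alike, and no supporting observation bears on this particular change.

The swap alters the halogen and its place on the ring together, so a 2-bromophenyl or a 4-fluorophenyl group would be needed to show whether each alteration alone also leaves the number unchanged, or whether two separate effects merely cancel here. Going by these compounds, it also remains open how far this flat reading extends beyond halogens, for example to a plain phenyl ring, a 4-methoxyphenyl group or a 4-aminophenyl group on the same nitrogen.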